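Swapping the amide aryl group for a nitrophenyl

A few compounds are considered here, and "the series" means these few. Any claim that something is new, unique, unknown or untested is made for them only; others in the source may bear on it.

compound 1 `Cc1cccc(NC(=O)c2ccc(/N=N\c3c[nH]c4ccccc34)cc2)c1C`: 106000 nM
compound 2 `O=C(Nc1cccc(Cl)c1)c1ccc(/N=N\c2c[nH]c3ccccc23)cc1`: 82700 nM
compound 3 `O=C(Nc1ccccc1F)c1ccc(/N=N\c2c[nH]c3ccccc23)cc1`: 83800 nM

Three compounds share one core and differ only in the aryl group attached to the amide-type nitrogen. In a functional assay on MCF7 cells (Homo sapiens) for inhibition, read by MTT assay, with a stated time of 72 h (a lower number here means a stronger inhibitor, a higher number a weaker inhibitor), compound 1 gives 106000 nM, compound 2 gives 82700 nM and compound 3 gives 83800 nM. Compound 3 thus holds the second highest of the three numbers, but every gap here is small: a 1.3-fold lower number from compound 1 to compound 2 (0.11 log units; within the scatter), a 1.3-fold lower number from compound 1 to compound 3 (0.10 log units; within the scatter) and a 1.0-fold higher number from compound 2 to compound 3 (0.01 log units; within the scatter) all lie within the usual scatter of repeated measurements, so no one of these compounds can be called stronger or weaker than another.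

Compound 4 `O=C(Nc1cccc([N+](=O)[O-])c1)c1ccc(/N=N\c2c[nH]c3ccccc23)cc1` continues this series. Its change from compound 3 is 3-nitrophenyl in place of 2-fluorophenyl on an amide-type nitrogen. All three measured steps bear on this move, since each exchanges one aryl group for another at the same amide-type nitrogen, and none of them shifted the number beyond the scatter. A further exchange of this kind is therefore expected to leave the number where it is, with no step beyond the scatter in either direction. Compound 4 is expected to give 85000 nM in this assay, within a range from 40000 nM to 180000 nM, which corresponds to an expected step of a 1.0-fold higher number from compound 3 to compound 4 (0.01 log units; within the scatter).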

Compound 4, half-maximal inhibitory concentration: 51900 nM
Beside the measured number, compound 4's estimate is 1.6-fold (0.21 log units) above it; the measured number falls inside the stated range.
By their numbers in this assay, from the lowest: compounds 4, 2, 3 and 1 (each within the scatter of the next, the first and the last beyond it).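

In this assay, within the data shown here, the 3-nitrophenyl group on the amide-type nitrogen gives the first step in this set that passes the scatter: a 2.0-fold lower number from compound 1 to compound 4 (0.31 log units; beyond the scatter), a modest step. Among these compounds, the other two steps stay within the scatter, a 1.6-fold lower number from compound 3 to compound 4 (0.21 log units; within the scatter) for the exchange of the 2-fluorophenyl group and a 1.6-fold lower number from compound 2 to compound 4 (0.20 log units; within the scatter) for nitro in place of chloro on an aromatic carbon, so the aryl group at this nitrogen can shift the number, but here only the pair of compound 1 and compound 4 shows it. Nothing available here gives a reason for this step, which stands as a difference in numbers alone.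

The compounds shown leave open whether an amine or a carboxylic acid on the phenyl ring would move the number further at this nitrogen, and in which direction. Also open, on these data alone, is what a longer chain would do in place of the aryl group on the amide-type nitrogen.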